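Dropping a Chloro Group: Expected Effect on Cytotoxicity

This account rests on a few compounds, and the source may have more. Where it says the series, first, only, none or still open, it means among the compounds named here.

compound 1 `CCOC(=O)c1c(-c2c(Cl)c3ccccc3oc2=O)nn(-c2ccc(OC)cc2)c1C(=O)OCC`: 18000 nM
compound 2 `CCOC(=O)c1c(-c2c(Cl)c3ccccc3oc2=O)nn(-c2cccc(Cl)c2)c1C(=O)OCC`: 38000 nM
compound 3 `CCOC(=O)c1c(-c2c(Cl)c3ccccc3oc2=O)nn(-c2ccc(Br)cc2)c1C(=O)OCC`: 30000 nM

These three compounds share one core and differ only in the aromatic group carried on the nitrogen. In a functional assay on A549 cells (Homo sapiens) for cytotoxicity, read by MTT assay, with a stated time of 48 h (a lower number here means a stronger inhibitor, a higher number a weaker inhibitor), compound 1 stands lowest of the three numbers. The step of a 1.7-fold higher number from compound 1 to compound 3 (0.22 log units; within the scatter) stays within the scatter, while the step of a 2.1-fold higher number from compound 1 to compound 2 (0.32 log units; beyond the scatter) lies just beyond it.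

Compound 4 `CCOC(=O)c1c(-c2cc3ccccc3oc2=O)nn(-c2ccc(OC)cc2)c1C(=O)OCC` has not yet been tested. It differs from compound 1 by hydrogen in place of chloro on an aromatic carbon. Among the compounds with values here, no measured step touches this position; all three concern the group on the nitrogen, and even the largest of them was modest. With nothing directly comparable, the removal of the chloro is expected to shift this assay only slightly, so the expected step is a 1.4-fold higher number from compound 1 to compound 4 (0.14 log units; within the scatter), most likely within the scatter. Compound 4 is therefore estimated at 25000 nM, with a range from 10000 nM to 60000 nM.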

Compound 4, half-maximal inhibitory concentration: 86000 nM
Estimate against measurement, compound 4: 3.4-fold (0.54 log units) below; the measured number lies above the stated range.
By their numbers in this assay, from the lowest: compounds 1, 3 and 2 (each within the scatter of the next, the first and the last beyond it); then compound 4.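

The chloro on the aromatic carbon opposite the ring oxygen counts for more in this assay than any group on the nitrogen so far: hydrogen in its place gives a 4.8-fold higher number from compound 1 to compound 4 (0.68 log units; beyond the scatter) and so a weaker inhibitor, a larger step than a 2.1-fold higher number from compound 1 to compound 2 (0.32 log units; beyond the scatter) on the nitrogen. Within the data shown here, this position, untouched by the earlier compounds, therefore affects the result. Nothing available explains this loss.

The compounds shown leave open what a methyl group or an amine would do at this position. Also open, on these data alone, is whether the chloro counts as much with 3-chlorophenyl or 4-bromophenyl on the nitrogen.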